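This account rests on a few compounds, and the source may have more. Where it says the series, first, only, none or still open, it means among the compounds named here.

Of the compounds shown here, three of a shared core have been measured in a functional assay on SH-SY5Y cells (Homo sapiens) for cytotoxicity, read by MTT assay, with a stated time of 72 h; a lower number here means a stronger inhibitor, a higher number a weaker inhibitor. Compound 1 `CN1CCN(CCCCCCn2c3c(c4ccccc42)C(=O)c2c[n+]([O-])c4ccccc4c2C3=O)CC1` gives 920 nM in this assay. Compound 3 `O=C1c2c[n+]([O-])c3ccccc3c2C(=O)c2[nH]c3ccccc3c21`, which carries a hydrogen on the aromatic nitrogen of the core, gives 1380 nM. For the measured compounds named here, compound 2 `O=C1c2c[n+]([O-])c3ccccc3c2C(=O)c2c1c1ccccc1n2Cc1cn(C[C@@H](O)CO)nn1` is reported in this assay only as a limit, > 500 nM, so for compound 2 no number is known, only that its value lies beyond that bound.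

Compound 4 `O=C1c2c[n+]([O-])c3ccccc3c2C(=O)c2c1c1ccccc1n2Cc1cn([C@H]2O[C@H](CO)[C@@H](O)[C@H]2O)nn1` is the next compound to be measured. It differs from compound 2 in one place: 3,4-dihydroxy-5-(hydroxymethyl)oxolan-2-yl in place of 2,3-dihydroxypropyl on an aromatic nitrogen. Going by the values given here, two measured steps touch compound 2 and might bear on this change. The step that the limit leaves unreadable from compound 1 to compound 2 cannot be sized, and the step that the limit leaves unreadable from compound 2 to compound 3 cannot be sized either, because of the limit of > 500 nM in this assay, at which 1 of the 3 values shown sits. Neither step therefore tells in which direction, or by how much, a change on that aromatic nitrogen moves the value in this assay. Compounds 1 and 3 show what the core does with other groups on that nitrogen, and both sit in the same broad region.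

With no readable step to lean on, compound 4 is expected to give about 1200 nM in this assay, somewhere between 400 nM and 4000 nM, and the step that the limit leaves unreadable from compound 2 to compound 4 is expected to be small.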

Compound 4, half-maximal inhibitory concentration: 1340 nM
The estimate for compound 4 lay 1.1-fold (0.05 log units) below the measured number, and the stated range covers the measured number.
By their numbers in this assay, from the lowest: compounds 1, 4 and 3 (each within the scatter of the next).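

No new step can be read, because compound 2, the partner of compound 4 in the only new pair, is known solely as a limit: the limit of > 500 nM in this assay, at which 1 of the 4 values shown sits.

The compounds shown leave open whether 3,4-dihydroxy-5-(hydroxymethyl)oxolan-2-yl in place of 2,3-dihydroxypropyl moves the value at all, and if it does, in which direction and how far.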